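This account rests on a few compounds, and the source may have more. Where it says the series, first, only, none or still open, it means among the compounds named here.

Working notes on the series. In an ADME assay on HT-29 cells (Homo sapiens) for cytotoxicity, read by MTT assay, with a stated time of 72 h (a higher number here means a weaker inhibitor, a lower number a stronger inhibitor), compound 1 (`COc1ccc(C2=C(c3cc(OC)c(OC)c(OC)c3)C(=O)C(O)C2)cc1NC(=O)c1ccccc1`) gives > 100 ug/mL, which is a limit of the assay and not a number. Compound 1 thus stands at the limit of > 100 ug/mL in this assay, at which 1 of the 3 values shown sits. Compound 2 (`COc1ccc(C2=C(c3cc(OC)c(OC)c(OC)c3)C(=O)CC2O)cc1O`) gives < 1 ug/mL, also a limit and not a number. Compound 3 (`COc1ccc(C2=C(c3cc(OC)c(OC)c(OC)c3)C(=O)C(OC(C)=O)C2)cc1O`) gives < 1 ug/mL, again only a limit. These limits leave the true gaps between the three compounds open.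

The next compound to be read is compound 4 (`COc1ccc(C2=C(c3cc(OC)c(OC)c(OC)c3)C(=O)C(O)C2)cc1OC(C)C`), which keeps the core of compound 1 and changes one group: isopropoxy in place of benzamido on an aromatic carbon. In words, isopropoxy stands in place of benzamido on an aromatic carbon, ortho to a methoxy group and meta to a large group.

Among the measured compounds shown here, no measured pair isolates this change. A large step towards a lower number, meaning a stronger inhibitor, is still expected in this assay. That expectation rests on compound 2, which lacks benzamido and has the limit < 1 ug/mL. For the measured compounds named here, no measured compound carries isopropoxy, so the size of the step is uncertain, and a result at either limit remains possible.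

The expected change is an at least 20-fold lower number from compound 1 to compound 4 (1.30 log units; beyond the scatter). For compound 4 the estimated value is 5 ug/mL, with an expected range of 0.5 ug/mL to 60 ug/mL.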

Compound 4, half-maximal inhibitory concentration: > 100 ug/mL
Compound 4 ended at the assay's limit (the forecaster's own chance of this, stated with the estimate: 35%); middle value at least 20-fold (1.30 log units) from the limit.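

In this assay compound 4 gives > 100 ug/mL, a limit of the assay and not a number, so no step between compound 1 and compound 4 can be read: the limit of > 100 ug/mL in this assay, at which 2 of the 4 values shown sit.

The compounds shown leave open what size of change, if any, isopropoxy in place of benzamido on an aromatic carbon brings.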